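Replacing a methyl with a pyridinyl-ethenyl arm

The source may hold more compounds than are shown below. What is called first, only, known or untested is meant among the compounds shown, and "the series" means these compounds.

Compound 3 `Cc1nc2ccccc2nc1OCC(=O)Nc1ccc(Cl)cc1` was tested in a functional assay on cells (Homo sapiens) for inhibition, read by MTT assay, with a stated time of 24 h; on this read-out lower numbers stand for stronger inhibition and higher numbers for weaker inhibition. There compound 3 gives only a limit of the assay, > 100000 nM. Two related compounds already carry the group that compound 4 gains: compound 1 `O=C(Cn1c(=O)c(/C=C\c2ccncc2)nc2ccccc21)Nc1ccccc1` and compound 2 `O=C(Cn1c(=O)c(/C=C\c2ccncc2)nc2ccccc21)Nc1ccc(Cl)cc1`. In this assay compound 1 likewise gives a limit, > 100000 nM. Compound 2 also gives a limit, > 100000 nM. Among the compounds with values here, the single measured step, a step that the two limits leave unreadable from compound 1 to compound 2, therefore yields no readable size. Compound 4 `O=C(COc1nc2ccccc2nc1/C=C\c1ccncc1)Nc1ccc(Cl)cc1` differs from compound 3 by 2-(pyridin-4-yl)ethenyl in place of methyl on an aromatic carbon. Within the data shown here, no measured step bears directly on this change; what stands is the limit of > 100000 nM in this assay, at which 3 of the 3 values shown sit. Compound 4 is expected to stay at that limit. The expected step is a number no higher from compound 3 to compound 4 (the limit leaves the size open). Compound 4 is estimated at 100000 nM, between 30000 nM and 300000 nM.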

Compound 4, half-maximal inhibitory concentration: > 100000 nM
Compound 4 was reported as a limit (the forecaster's own chance of this, stated with the estimate: 75%); the middle value lies on the limit itself.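

Compound 3 and compound 4 each give only a limit, so no size can be read for the change between them, and the picture stands: the limit of > 100000 nM in this assay, at which 4 of the 4 values shown sit.

The compounds shown leave open how large that change really is, and whether any of them reaches a readable value.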